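Swapping the para substituent on the anilide of a GST Mu 2 inhibitor

The compounds below may be only part of what the source reports. "The series", "measured", "known", "first", "only" and "open" are said of these compounds alone.

Measured compounds:
compound 1 `Cc1ccccc1NC(=O)CCC(=O)OCCCCCCSc1ccc([N+](=O)[O-])c2nonc12`: 440 nM
compound 2 `O=C(CCC(=O)OCCCCCCSc1ccc([N+](=O)[O-])c2nonc12)Nc1ccc(Br)cc1`: 32000 nM

In an assay on isolated protein for inhibition of glutathione S-transferase Mu 2 (Homo sapiens), with a stated time of 10 min (on this read-out higher numbers stand for weaker inhibition and lower numbers for stronger inhibition), compound 2 gives the highest of the two numbers, and the step of a 73-fold higher number from compound 1 to compound 2 (1.86 log units; beyond the scatter) is the only one measured. Compound 3 `COc1ccc(NC(=O)CCC(=O)OCCCCCCSc2ccc([N+](=O)[O-])c3nonc23)cc1` differs from compound 2 by methoxy in place of bromo on an aromatic carbon. Going by the values given here, no measured step changes a group para to a large group, so the measured step bears on this only loosely. A substituent remains para to a large group, so compound 3 is expected to stay near compound 2, with an estimated step of a 2.1-fold lower number from compound 2 to compound 3 (0.33 log units; beyond the scatter), giving an estimate of 15000 nM within 3000 nM to 80000 nM.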

Compound 3, half-maximal inhibitory concentration: 130 nM
Estimate against measurement, compound 3: 120-fold (2.06 log units) above; the whole stated range lies above it.
By their numbers in this assay, from the lowest: compound 3; then compound 1; then compound 2.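

This position is far from indifferent: methoxy in place of bromo gives a 250-fold lower number from compound 2 to compound 3 (2.39 log units; beyond the scatter), so one small substituent para to a large group can separate weak from strong inhibition. The 4-methoxyphenyl group also improves on the 2-methylphenyl group, with a 3.4-fold lower number from compound 1 to compound 3 (0.53 log units; beyond the scatter). Nothing available explains the gap between bromo and methoxy.

Going by these compounds, whether a hydroxyl, an amine or an ethoxy group on this carbon would behave like methoxy or like bromo remains open.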